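A few compounds are considered here, and "the series" means these few. Any claim that something is new, unique, unknown or untested is made for them only; others in the source may bear on it.

Measured so far in a toxicity assay on GES1 cells (Homo sapiens) for inhibition, read by MTT assay, with a stated time of 72 h; on this read-out higher numbers stand for weaker inhibition and lower numbers for stronger inhibition:

Compound 1, `Cc1cc(N2CC[C@@H](C)[C@@H](N(C)c3ncnc4[nH]ccc34)C2)n2nc(SCc3ccccc3)nc2n1`: compound 1 gives 67200 nM.
Compound 2, `C#CSc1nc2nc(C)cc(N3CC[C@@H](C)[C@@H](N(C)c4ncnc5[nH]ccc45)C3)n2n1`: compound 2 gives > 100000 nM, which is a limit of this assay and not a number.
Compound 3, `Cc1cc(N2CC[C@@H](C)[C@@H](N(C)c3ncnc4[nH]ccc34)C2)n2nc(SCc3csc4ccc(Cl)cc34)nc2n1`: compound 3 gives > 100000 nM, again a limit of this assay rather than a number.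

Compound 3 therefore stands at the top of what this assay reports; the limit of > 100000 nM in this assay, at which 2 of the 3 values shown sit, marks that ceiling, so its true inhibition of these cells is only known to be weak. Compound 4, `Cc1cc(N2CC[C@@H](C)[C@@H](N(C)c3ncnc4[nH]ccc34)C2)n2nc(SCc3ccc(F)cc3)nc2n1`, differs from compound 3 in one place: 4-fluorophenyl in place of 5-chloro-1-benzothiophen-3-yl on a saturated chain carbon bound to a sulfur. The measured step that bears on this is an at least 1.4-fold higher number from compound 1 to compound 3 (0.17 log units; that floor lies within the scatter), since compound 4 carries a 4-fluorophenyl close in size to the phenyl of compound 1. That step was a floor within the scatter, so the reverse change is expected to give no step beyond the scatter, with compound 4 landing near compound 1. The expected step is an at least 1.2-fold lower number from compound 3 to compound 4 (0.09 log units; that floor lies within the scatter), and compound 4 is estimated at 80000 nM, between 40000 nM and 200000 nM, with a real chance the assay again reports only a limit.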

Compound 4, half-maximal inhibitory concentration: 12300 nM
Compound 4: middle estimate off by 6.5-fold (0.81 log units), on the high side; the whole stated range lies above it.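

In this assay, within the data shown here, fluoro in place of hydrogen on an aromatic carbon gives a 5.5-fold lower number from compound 1 to compound 4 (0.74 log units; beyond the scatter), the first step with a measured size beyond the scatter, so the group on the sulfur responds even to a change at a single ring atom. The other two steps, an at least 8.1-fold lower number from compound 3 to compound 4 (0.91 log units; beyond the scatter) and an at least 8.1-fold lower number from compound 2 to compound 4 (0.91 log units; beyond the scatter), also pass the scatter, and compound 4 has the lowest number of the four, which here means the strongest inhibition of these cells. Those two steps are only floors, because compound 2 and compound 3 sit at the ceiling of the assay: the limit of > 100000 nM in this assay, at which 2 of the 4 values shown sit.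

A chloro or a methoxy on the same phenyl would show whether this drop belongs to fluoro alone. On these data alone, whether a longer chain between the sulfur and the 4-fluorophenyl keeps the drop also remains open.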